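This account rests on a few compounds, and the source may have more. Where it says the series, first, only, none or still open, it means among the compounds named here.

Measured compounds:

Compound 1 `N#Cc1ccc(Nc2nc(Oc3ccnc4ccccc34)nc(N3CCCCC3)n2)cc1C(F)(F)F` — in a functional assay on DU-145 cells (Homo sapiens) for cytotoxicity, read by sulforhodamine B assay, with a stated time of 48 h (a higher number here means that more compound is tolerated, a lower number that less compound is tolerated), compound 1 gives > 100000 nM, which is a limit of the assay.
Compound 2 `N#Cc1ccc(Nc2nc(Oc3ccnc4ccccc34)nc(N3CCN(c4ncccn4)CC3)n2)cc1C(F)(F)F` — in this assay compound 2 gives > 100000 nM, again a limit.
Compound 3 `N#Cc1ccc(Nc2nc(Oc3ccnc4ccccc34)nc(N3CCN(c4ccccc4F)CC3)n2)cc1C(F)(F)F` — in this assay compound 3 gives > 100000 nM, also a limit.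

Compound 3 therefore stands where every other measured member of the series stands: at the limit of > 100000 nM in this assay, at which 3 of the 3 values shown sit. Nothing in the numbers separates it from compound 1 or compound 2.

Compound 4 `CC(=O)N1CCN(c2nc(Nc3ccc(C#N)c(C(F)(F)F)c3)nc(Oc3ccnc4ccccc34)n2)CC1` is the next member. Its change from compound 3 is acetyl in place of 2-fluorophenyl on an amine nitrogen in a ring.

The steps already measured that bear on this position are a step that the two limits leave unreadable from compound 1 to compound 2 and a step that the two limits leave unreadable from compound 2 to compound 3. Both touch the same six-membered non-aromatic ring with two nitrogens or the group on its amine nitrogen, and both are unreadable, because the limit of > 100000 nM in this assay, at which 3 of the 3 values shown sit, covers each value at both ends. Within the data shown here, no measured step of readable size exists, so no direction can be inferred for the acetyl in place of 2-fluorophenyl.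

For compound 4 the working expectation in this assay is that the step that the limit leaves unreadable from compound 3 to compound 4 stays within the scatter. Compound 4 is accordingly expected at 150000 nM, with a range of 50000 nM to 500000 nM, and most probably the assay will again report only a limit.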

Compound 4, concentration lethal to 50% of the cells: > 100000 nM
Compound 4 ended at the assay's limit (the forecaster's own chance of this, stated with the estimate: 85%); the middle value does not contradict the limit.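

Among these compounds, no step among compound 1, compound 2, compound 3 and compound 4 can be read in this assay because every value is a limit of the assay, not a number: the limit of > 100000 nM in this assay, at which 4 of the 4 values shown sit.
The compounds shown leave open whether any change to the group on the amine nitrogen in the ring, or to that ring itself, alters cytotoxicity.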